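The source may hold more compounds than are shown below. What is called first, only, known or untested is meant among the compounds shown, and "the series" means these compounds.

Compound 1 `O=C(Nc1cccc(-c2oc3cc(-c4ccc(F)cc4)ccc3c(=O)c2O)c1)c1ccccc1F` carries a 2-fluorophenyl group on a carbonyl carbon whose other neighbour is an amide-type nitrogen. Going by the values given here, in a functional assay on HepG2 cells (Homo sapiens) for antiproliferative activity, read by CCK-8 assay, with a stated time of 72 h (on this read-out higher numbers stand for weaker inhibition and lower numbers for stronger inhibition), compound 1 gives 10100 nM, the lowest of the two numbers measured so far. Compound 2 `O=C(Nc1cccc(-c2oc3cc(-c4ccc(F)cc4)ccc3c(=O)c2O)c1)c1ccc(C(F)(F)F)cc1` has 4-(trifluoromethyl)phenyl in place of 2-fluorophenyl on that carbonyl carbon, and in this assay compound 2 gives 42700 nM. Among the compounds with values here, the only measured step at this position is a 4.2-fold higher number from compound 1 to compound 2 (0.63 log units; beyond the scatter).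

Compound 3 `O=C(Nc1cccc(-c2oc3cc(-c4ccc(F)cc4)ccc3c(=O)c2O)c1)c1ccc(Cl)nc1` has not yet been measured. Its difference from compound 1 is 6-chloropyridin-3-yl in place of 2-fluorophenyl on a carbonyl carbon. The one measured comparison that bears on this change is the swap of the ring on the carbonyl carbon described above, which produced a modest rise beyond the scatter. Because of a 4.2-fold higher number from compound 1 to compound 2 (0.63 log units; beyond the scatter), a further change of the ring at the same place is expected to move the number upward by a small amount, though the two changes are not alike and a step within the scatter is also plausible. Compound 3 is therefore expected to give 20000 nM, with a range from 7000 nM to 60000 nM in this assay. This estimate means an expected step of a 2.0-fold higher number from compound 1 to compound 3 (0.30 log units; within the scatter).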

Compound 3, half-maximal inhibitory concentration: 4610 nM
Estimate against measurement, compound 3: 4.3-fold (0.64 log units) above, and the stated range ends above it.
By their numbers in this assay, from the lowest: compound 3; then compound 1; then compound 2.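

The ring on this carbonyl carbon can push the number in either direction: the earlier comparison showed only a rise, whereas in this assay this change gives a 2.2-fold lower number from compound 1 to compound 3 (0.34 log units; beyond the scatter). Going by these compounds alone, it also shows that the place tolerates a ring with a nitrogen atom in it, and that the choice of ring matters more than the single earlier step suggested, with a 9.3-fold lower number from compound 2 to compound 3 (0.97 log units; beyond the scatter), so compound 3 is the strongest of the three in this assay. Nothing available explains why the 6-chloropyridin-3-yl ring gives the lowest number.

This swap changes two things at once, a ring nitrogen entering and a chlorine replacing the fluorine, so the three compounds cannot show which of the two goes with the lower number. From the compounds shown here alone, a plain pyridin-3-yl ring without the chlorine, or a pyridin-3-yl ring carrying an amine in place of the chlorine, would help to separate these two parts of the change, and it remains open whether either would keep the number as low as in compound 3.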